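The compounds below may be only part of what the source reports. "The series", "measured", "known", "first", "only" and "open" are said of these compounds alone.

Measured in a functional assay on MDA-MB-231 cells (Homo sapiens) for antiproliferative activity, read by MTT assay, with a stated time of 48 h; on this read-out higher numbers stand for weaker inhibition and lower numbers for stronger inhibition:
- compound 1 `C=CS(=O)(=O)N1CCN(c2ncnc3sc(-c4ccc(C#N)cc4)cc23)CC1`: 8050 nM
- compound 2 `C=CS(=O)(=O)N1CCN(c2ncnc3sc(-c4ccc(OC)nc4)cc23)CC1`: 9270 nM

Compound 2 lies within the scatter of compound 1, so the two cannot be ordered. Compound 3 `C=CS(=O)(=O)N1CCN(c2ncnc3sc(-c4c(C)noc4C)cc23)CC1` carries 3,5-dimethyl-1,2-oxazol-4-yl in place of 6-methoxypyridin-3-yl on an aromatic carbon. Among the compounds with values here, the one measured step at this place, a 1.2-fold higher number from compound 1 to compound 2 (0.06 log units; within the scatter), stayed within the scatter, but neither measured compound has a five-membered aromatic ring there, so the evidence is thin. In this assay the expected change is a 1.1-fold higher number from compound 2 to compound 3 (0.03 log units; within the scatter), with no step beyond the scatter and no direction expected. For compound 3 the estimated value is 10000 nM, with an expected range of 4000 nM to 25000 nM.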

Compound 3, half-maximal inhibitory concentration: 28200 nM
For compound 3 the middle estimate is 2.8-fold (0.45 log units) below the measured one; the measured number lies above the stated range.
By their numbers in this assay, from the lowest: compounds 1 and 2 (each within the scatter of the next); then compound 3.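

In this assay the position next to the ring sulfur proves sensitive to the group it carries, with 3,5-dimethyl-1,2-oxazol-4-yl giving a 3.0-fold higher number from compound 2 to compound 3 (0.48 log units; beyond the scatter) and a 3.5-fold higher number from compound 1 to compound 3 (0.54 log units; beyond the scatter). The six-membered aromatic groups of compound 1 and compound 2 sit within the scatter of each other, so the weakening appears only with the five-membered aromatic ring, in this single example. No measured evidence accounts for the change. Open, as far as these compounds go, is whether the step follows the five-membered ring itself or its two methyl groups, and how an unsubstituted 1,2-oxazol-4-yl or a phenyl carrying an amine or a carboxylic acid would read.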